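Thiophene-to-pyrrole swap on the exocyclic chain carbon

The compounds below may be only part of what the source reports. "The series", "measured", "known", "first", "only" and "open" are said of these compounds alone.

Three compounds have been run in a functional assay on PLC5 cells (Homo sapiens) for cytotoxicity, read by MTT assay (a lower number here means a stronger inhibitor, a higher number a weaker inhibitor), so far. Compound 1 `COc1cc(-c2cc3ccccc3[nH]2)[nH]c1C=C1SCCCS1` sits at the limit of the assay, > 40000 nM, which is a limit and not a number; (the limit of > 40000 nM in this assay, at which 1 of the 3 values shown sits). Compound 2 `COC1=CC(c2cccs2)=N/C1=C\c1cccs1` gives 25900 nM in this assay, the highest of the two numbers obtained, and compound 3 `COC1=CC(c2cc3cc(Br)ccc3[nH]2)=N/C1=C\c1ccc[nH]1` gives 6300 nM, a gap that lies beyond the scatter. Among the compounds with values here, no pair of measured compounds differs in a single place, so no measured step is available.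

Compound 4 `COC1=CC(c2cccs2)=N/C1=C\c1ccc[nH]1` remains to be tested. It differs from compound 2 in one place: 1H-pyrrol-2-yl in place of thiophen-2-yl on a double-bonded chain carbon bound to a double-bonded ring carbon. Compound 3 also carries 1H-pyrrol-2-yl on that chain carbon and gives 6300 nM, whereas compound 2, with thiophen-2-yl there, gives 25900 nM; the two also differ elsewhere, so this comparison is only suggestive. On that basis a modest step toward a lower number is expected, a 1.7-fold lower number from compound 2 to compound 4 (0.24 log units; within the scatter), though it may not exceed the scatter. Compound 4 is expected to give 15000 nM, with a range of 5000 nM to 40000 nM.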

Compound 4, half-maximal inhibitory concentration: > 40000 nM
Compound 4: a limit, no number; the forecaster's own chance of this, stated with the estimate: 15%; middle value at least 2.6-fold (0.42 log units) away from the limit.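

In this assay, within the data shown here, 1H-pyrrol-2-yl in place of thiophen-2-yl on a double-bonded chain carbon bound to a double-bonded ring carbon gives the first single-place step, an at least 1.5-fold higher number from compound 2 to compound 4 (0.18 log units; that floor lies within the scatter), so this change brings no lower number here. That step is only a floor because compound 4 stands at a limit and not at a number: the limit of > 40000 nM in this assay, at which 2 of the 4 values shown sit.

With 1H-pyrrol-2-yl on that chain carbon in both compounds, the number of compound 3, 6300 nM, cannot be credited to that group alone.

As far as these compounds go, how far compound 4 lies past its limit stays open, so the full size of the step cannot be read. Also open, from the compounds shown here alone, is how furan-2-yl or a phenyl ring on that chain carbon would read alongside the thiophen-2-yl of compound 2.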